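Acid ceramidase series: benzyl for acetyl on ring amine

A few compounds are considered here, and "the series" means these few. Any claim that something is new, unique, unknown or untested is made for them only; others in the source may bear on it.

Measured so far in an assay on HEK293 cells for inhibition of acid ceramidase (Homo sapiens), read by fluorescence, with stated times of 10 min and 3 h; on this read-out higher numbers stand for weaker inhibition and lower numbers for stronger inhibition:
compound 1 `CC(=O)N1CCc2oc(=O)n(C(=O)NCCCCc3ccccc3)c2C1`: 293 nM
compound 2 `CC(=O)N1CCC(c2ccc3c(c2)oc(=O)n3C(=O)NCCCCc2ccccc2)CC1`: 64 nM

Two numbers are known. Compound 1 gives the higher of them in this assay, and compound 2 the lower; the gap between the two lies beyond the usual scatter, so on these two points compound 1 is the weaker inhibitor. The two compounds differ in more than one place, so nothing is drawn from that pair about any single change.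

The next compound, compound 3 `O=C(NCCCCc1ccccc1)n1c2c(oc1=O)CCN(Cc1ccccc1)C2`, keeps the core of compound 1 and changes only the amine substituent: benzyl in place of acetyl on an amine nitrogen in a ring. Within the data shown here, no step isolates the effect of a benzyl group in place of an acetyl group on this ring nitrogen, so the direction is open. Compound 3 is expected to land near compound 1, with the step from compound 1 to compound 3 estimated at a 1.3-fold lower number from compound 1 to compound 3 (0.12 log units; within the scatter), not clearly beyond the scatter. For compound 3 the estimate in this assay is 220 nM, within a range from 60 nM to 800 nM.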

Compound 3, half-maximal inhibitory concentration: 436 nM
Estimate against measurement, compound 3: 2.0-fold (0.30 log units) below; measured number inside the range.
By their numbers in this assay, from the lowest: compound 2; then compounds 1 and 3 (each within the scatter of the next).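

In this assay, benzyl in place of acetyl on the amine nitrogen in the ring gives a 1.5-fold higher number from compound 1 to compound 3 (0.17 log units; within the scatter) and so does not separate the two groups. On the core of compound 1, this position therefore tolerates benzyl, with its six-membered aromatic ring and 7 heavy atoms, as well as acetyl, with its 3 heavy atoms and 1 hydrogen-bond acceptor. No available evidence bears on why these two substituents read alike.

Going by these compounds, whether the ring nitrogen tolerates a wider range of groups remains open, for instance with a free amine, a methanesulfonyl group or a benzyl group carrying a carboxylic acid. Compound 2 differs from compound 1 and compound 3 in more than one place, so its lower number cannot be assigned to any single change.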